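Ethynyl to thiophen-2-yl in a growth inhibition series

The compounds below may be only part of what the source reports. "The series", "measured", "known", "first", "only" and "open" are said of these compounds alone.

Compound 1 (`COc1ccc(Cn2nnc3c(C(N)=O)ncn3c2=O)cc1`) gives > 50000 nM
Compound 2 (`C[C@@H](c1ccccc1)n1nnc2c(C(N)=O)ncn2c1=O`) gives 34700 nM
Compound 3 (`C#CC/N=N/Nc1[nH]cnc1C(N)=O`) gives 39100 nM

All three compounds were tested in a functional assay on SNB-19 cells (Homo sapiens) for inhibition, read by MTT assay, with a stated time of 7 days (a higher number here means a weaker inhibitor of growth, a lower number a stronger inhibitor of growth), and only two of them returned a number. For compound 1 the entry > 50000 nM is a limit and not a number. Compound 3, at 39100 nM in this assay, lies within the scatter of compound 2 at (34700 nM), so the two cannot be ordered.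

The next compound to be measured is compound 4 (`NC(=O)c1nc[nH]c1N/N=N/Cc1cccs1`). It carries thiophen-2-yl in place of ethynyl on a saturated chain carbon bound to a double-bonded nitrogen.

Going by the values given here, no two measured compounds differ in one place only, so no measured step shows how large such a change might be. In this assay no change beyond the scatter is expected, in either direction, and this expectation rests on compound 3 at (39100 nM). The expected change is a 1.0-fold lower number from compound 3 to compound 4 (0.01 log units; within the scatter) and would leave the two compounds within the scatter of each other. The estimated value for compound 4 is 38000 nM with an expected range (18000 nM to 60000 nM).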

Compound 4, concentration for 50% growth inhibition: > 50000 nM
Compound 4: only a limit was reported; the forecaster's own chance of this, stated with the estimate: 35%; middle value at least 1.3-fold (0.11 log units) from the limit.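

In this assay compound 4 gives > 50000 nM and this entry is a limit, not a number. Going by these compounds alone, the exchange of ethynyl for thiophen-2-yl on a saturated chain carbon bound to a double-bonded nitrogen is the first single change that can be read, and it appears as an at least 1.2-fold higher number from compound 3 to compound 4 (0.10 log units; that floor lies within the scatter) and so the two compounds cannot be ordered on this floor alone, although thiophen-2-yl brought no sign of stronger growth inhibition at this place. The true size of the step stays unread because the reading stops at a limit: the limit of > 50000 nM in this assay, at which 2 of the 4 values shown sit.

On these data alone, with only ethynyl and thiophen-2-yl read at this place, it remains open whether any group there can move the number clearly in either direction. A furan-2-yl ring, an amine, a carboxylic acid or a longer saturated chain at the same place could show whether the ring, the chain or neither matters for growth inhibition in this assay at all.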